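A few compounds are considered here, and "the series" means these few. Any claim that something is new, unique, unknown or untested is made for them only; others in the source may bear on it.

In an ADME assay on microsomes from liver (Mus musculus) for metabolic stability (on this read-out higher numbers stand for a longer-lived compound and lower numbers for a shorter-lived compound), compound 2 `CC(C)C(CC(N)=O)c1ccc(-c2ccc3cccc(F)c3c2)[nH]c1=O` gives < 0.0667 h, which is a limit of the assay and not a number. Its closest measured relative, compound 1 `CC(C)C(c1ccc(-c2ccc3cccc(F)c3c2)[nH]c1=O)N1CCCCS1(=O)=O`, gives 0.0733 h in this assay. The next structure, compound 3 `CC(C)NC(=O)CC(c1ccc(-c2ccc3cccc(F)c3c2)[nH]c1=O)C(C)C`, carries isopropyl in place of hydrogen on an amide-type nitrogen. Among the measured compounds shown here, only one measured step bears on this change, an at least 1.0-fold lower number from compound 1 to compound 2 (0.04 log units; that floor lies within the scatter). That step exchanged a whole side group and stayed within the scatter, but it did not test this nitrogen, so it offers only loose guidance. No step beyond the scatter is therefore expected in this assay, and the limit on compound 2 leaves the true size of any step open. The expected step is an at least 1.0-fold higher number from compound 2 to compound 3 (0.02 log units; that floor lies within the scatter). For compound 3 the estimated half-life is 0.07 h, with an expected range from 0.04 h to 0.14 h.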

Compound 3, half-life: < 0.0667 h
Compound 3 gave a limit, no number (the forecaster's own chance of this, stated with the estimate: 60%); middle value at least 1.0-fold (0.02 log units) from the limit.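

With isopropyl on the amide-type nitrogen, compound 3 also gives only a limit of the assay in this assay, not a number. This nitrogen has now been tested directly, and neither hydrogen nor isopropyl there yields a readable half-life, so the step between compound 2 and compound 3 cannot be read: the limit of < 0.0667 h in this assay, at which 2 of the 3 values shown sit.

Set against the six-membered ring side group of the closest relative with a real number, the new amide side group gives an at least 1.0-fold lower number from compound 1 to compound 3 (0.04 log units; that floor lies within the scatter).

Still open, as far as these compounds go, is whether a methyl group on this nitrogen, or a carboxylic acid in place of the whole amide, would give a readable number in this assay. From the compounds shown here alone, how far compound 2 and compound 3 truly lie apart also stays unknown.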